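The source may report more compounds than this note shows. Statements on the series, on what has been measured and on what is new or still open speak of the compounds shown alone.

Measured in a functional assay on MCF7 cells (Homo sapiens) for cytotoxicity, read by MTT assay, with a stated time of 72 h; on this read-out higher numbers stand for weaker inhibition and lower numbers for stronger inhibition:
- compound 1 `CCNc1cc2nc(-c3ccccc3)nn(-c3ccccc3)c-2cc1=O`: 1620 nM
- compound 2 `O=c1cc2n(-c3ccccc3)nc(-c3ccccc3)nc-2cc1N1CCCC1`: 360 nM
- compound 3 `CC(=O)Nc1cc2nc(-c3ccccc3)nn(-c3ccccc3)c-2cc1=O`: > 5000 nM, a limit and not a number

Compound 3 sits at the weak end of this small set, and its > 5000 nM is only a limit. Compound 4 `CCOc1cc2nc(-c3ccccc3)nn(-c3ccccc3)c-2cc1=O` has ethoxy in place of acetamido on an aromatic carbon. Among the measured compounds shown here, two measured steps bear on this change, as both end at the acetamido compound: an at least 3.0-fold higher number from compound 1 to compound 3 (0.48 log units; beyond the scatter) and an at least 13-fold higher number from compound 2 to compound 3 (1.14 log units; beyond the scatter). Read backwards, they suggest that losing acetamido should lower the number in this assay. Neither step involves ethoxy, so the size is uncertain. Compound 1, whose ethylamino group also has no ring, gives 1620 nM, which points to a modest step rather than a large one. The expected change is an at least 3.3-fold lower number from compound 3 to compound 4 (0.52 log units; beyond the scatter). For compound 4 the estimated value is 1500 nM, with an expected range from 500 nM to 4500 nM.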

Compound 4, half-maximal inhibitory concentration: > 5000 nM
Compound 4 was reported as a limit; the forecaster's own chance of this, stated with the estimate: 15%; at least 3.3-fold (0.52 log units) between middle value and limit.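

Compound 4 gives only a limit, > 5000 nM, so ethoxy in place of acetamido on this aromatic carbon brings no readable gain. Ethoxy also falls behind both groups that gave a number, with an at least 3.0-fold higher number from compound 1 to compound 4 (0.48 log units; beyond the scatter) and an at least 13-fold higher number from compound 2 to compound 4 (1.14 log units; beyond the scatter). The step between compound 3 and compound 4 cannot be read because both stop at the same limit: the limit of > 5000 nM in this assay, at which 2 of the 4 values shown sit.

Going by these compounds, whether a piperidin-1-yl ring or a dimethylamino group on this carbon would match compound 2 at 360 nM stays open. So does whether a longer chain on the ethoxy oxygen would give a measurable number at all.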